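Notes on a B-cell series: amine side-chain variation

The compounds below may be only part of what the source reports. "The series", "measured", "known", "first", "only" and "open" are said of these compounds alone.

Measured compounds:
Compound 1 `CCOC(=O)Cn1c(=O)n(C2OC(CO)[C@@H](O)[C@H]2O)c2nc(N)nc(O)c21` gives 86% in a functional assay on the whole organism (B cells) with Mus musculus as the target; a higher number here means a larger maximal response, a lower number a smaller maximal response.
Compound 2 `Nc1nc(O)c2c(n1)n(C1OC(CO)[C@@H](O)[C@H]1O)c(=O)n2Cc1ccccc1` gives 110% in this assay.
Compound 3 `CN(C)CCCn1c(=O)n(C2OC(CO)[C@@H](O)[C@H]2O)c2nc(N)nc(O)c21` gives 83% in this assay.

Compound 3 stands lowest of the three numbers. For the measured compounds named here, its nearest neighbour is compound 1, and that gap, a number 3 percentage points lower from compound 1 to compound 3 (within the scatter), lies within the scatter; the only step set apart from it is a number 27 percentage points lower from compound 2 to compound 3 (beyond the scatter).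

Compound 4 `Nc1nc(O)c2c(n1)n(C1OC(CO)[C@@H](O)[C@H]1O)c(=O)n2CCN1CCCCC1` differs from compound 3 by piperidin-1-yl in place of (dimethylamino)methyl on a saturated chain carbon, two bonds along the chain from an aromatic nitrogen.

Of the measured steps, a number 3 percentage points lower from compound 1 to compound 3 (within the scatter) and a number 27 percentage points lower from compound 2 to compound 3 (beyond the scatter) both involve compound 3, but each exchanges the whole group on the saturated chain carbon bound to the aromatic nitrogen, and a number 24 percentage points higher from compound 1 to compound 2 (beyond the scatter) is an exchange at that same carbon. Going by the values given here, no measured step swaps one amine for another two bonds along the chain, so none bears directly on the change to compound 4. The expectation therefore rests on compound 3 alone, and a number 2 percentage points higher from compound 3 to compound 4 (within the scatter) is expected to stay within the scatter, with no direction claimed. Compound 4 is estimated at 85% in this assay, with a range from 68% to 102%.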

Compound 4, largest response reached (reported as maximal response), in percent of the reference or control that the assay uses: 0%
Compound 4: middle estimate off by 85 percentage points, on the high side; measured number outside the range, below it.
By their numbers in this assay, from the lowest: compound 4; then compounds 3 and 1 (each within the scatter of the next); then compound 2.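

In this assay, this position proves sensitive to the form of the amine: replacing (dimethylamino)methyl with piperidin-1-yl, on a saturated chain carbon two bonds along the chain from an aromatic nitrogen, gives a number 83 percentage points lower from compound 3 to compound 4 (beyond the scatter), whereas the earlier side-chain exchanges had left a measurable response throughout. Compound 4 also falls far short of the two non-amine compounds, with a number 110 percentage points lower from compound 2 to compound 4 (beyond the scatter) and a number 86 percentage points lower from compound 1 to compound 4 (beyond the scatter), so an amine-bearing chain is not tolerated regardless of its form, and compound 3 shows that such a chain alone does not remove the response. Nothing available explains the loss of response at this position.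

Read one bond further out, the same step runs from 3-(dimethylamino)propyl to 2-(piperidin-1-yl)ethyl, so the piperidine ring and the chain length change together and their contributions remain unseparated. A 3-(piperidin-1-yl)propyl group would keep the chain of compound 3 while carrying the ring of compound 4, and would show which of the two changes tracks with the response.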